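A few compounds are considered here, and "the series" means these few. Any claim that something is new, unique, unknown or untested is made for them only; others in the source may bear on it.

Working notes on the series. Within the data shown here, in a functional assay on PC-3 cells (Homo sapiens) for inhibition, read by sulforhodamine B assay, with a stated time of 48 h (a higher number here means a weaker inhibitor of growth, a lower number a stronger inhibitor of growth), compound 1 `COc1ccc(/C=N/NC(=S)NC(C)(C)[C@H]2CC=C(C)CC2)cc1` gives 1200 nM, the second highest of the three numbers measured so far. Compound 2 `CC1=CC[C@H](C(C)(C)NC(=S)N/N=C/c2ccccc2O)CC1` gives 900 nM in this assay, and compound 3 `CC1=CC[C@H](C(C)(C)NC(=S)N/N=C/c2cccc(Cl)c2)CC1` gives 6600 nM. The move a 1.3-fold lower number from compound 1 to compound 2 (0.12 log units; within the scatter) stays within the scatter, whereas a 5.5-fold higher number from compound 1 to compound 3 (0.74 log units; beyond the scatter) and a 7.3-fold higher number from compound 2 to compound 3 (0.87 log units; beyond the scatter) both lie beyond it. Compound 4 `CC1=CC[C@H](C(C)(C)NC(=S)N/N=C/c2ccc(Cl)cc2)CC1` has not yet been measured in this assay. It differs from compound 1 by chloro in place of methoxy on an aromatic carbon. Among the measured compounds shown here, no measured step makes exactly this exchange; the nearest is the one to compound 3, in which a chloro-bearing phenyl also replaced the 4-methoxyphenyl, though with the chloro in the 3-position, and the number rose by a 5.5-fold higher number from compound 1 to compound 3 (0.74 log units; beyond the scatter). For the measured compounds named here, because of a 5.5-fold higher number from compound 1 to compound 3 (0.74 log units; beyond the scatter) a rise in the number is expected for compound 4, but a smaller one, as only a single step bears on it and it is not the same exchange. Compound 4 is therefore expected to give 2500 nM, with a range from 1000 nM to 7000 nM. That expectation corresponds to a step of a 2.1-fold higher number from compound 1 to compound 4 (0.32 log units; beyond the scatter).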

Compound 4, concentration for total growth inhibition: 1700 nM
Compound 4: middle estimate off by 1.5-fold (0.17 log units), on the high side; measured number inside the range.
By their numbers in this assay, from the lowest: compounds 2, 1 and 4 (each within the scatter of the next); then compound 3.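

In this assay, chloro in place of methoxy on an aromatic carbon para to a large group leaves the number within the scatter (a 1.4-fold higher number from compound 1 to compound 4 (0.15 log units; within the scatter)), and the 4-chlorophenyl compound also stays within the scatter of the 2-hydroxyphenyl one (a 1.9-fold higher number from compound 2 to compound 4 (0.28 log units; within the scatter)). The rise seen earlier with compound 3 therefore does not follow from a chloro-bearing phenyl as such, since 4-chlorophenyl in place of 3-chlorophenyl gives a step beyond the scatter (a 3.9-fold lower number from compound 3 to compound 4 (0.59 log units; beyond the scatter)), so the placing of the chloro on the ring counts in this pair. No measured evidence accounts for this difference.

The compounds shown leave open whether a group of another kind at the same place, such as a dimethylamino group, a carboxylic acid or a longer chain like butoxy, would keep the number in this range. They also leave open whether the difference between the two chloro placings holds for other groups, such as bromo or trifluoromethyl.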